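A Difluorobenzyl Variant of a Fluoroalkyl Adenosine Analogue

The compounds below may be only part of what the source reports. "The series", "measured", "known", "first", "only" and "open" are said of these compounds alone.

Compound 1, `O[C@@H]1[C@H](O)[C@@H]2C[C@@H]2[C@H]1n1cnc2c(NC3CCCCCC3)nc(Cl)nc21`, in an assay on CHO cells for displacement of a labelled ligand from adenosine receptor A3 (Homo sapiens), with a stated time of 60 min (on this read-out lower numbers stand for stronger inhibition and higher numbers for weaker inhibition), gives 560 nM.
Compound 2, `O[C@@H]1[C@H](O)[C@@H]2C[C@@H]2[C@H]1n1cnc2c(NCCCF)nc(Cl)nc21`, in this assay gives 32.4 nM.
Compound 3, `O[C@@H]1[C@H](O)[C@@H]2C[C@@H]2[C@H]1n1cnc2c(NCc3ccccc3OCCF)nc(Cl)nc21`, in this assay gives 10.3 nM.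

Compound 2 holds the second highest of the three numbers in this assay; compound 1 lies furthest from it, with a 17-fold lower number from compound 1 to compound 2 (1.24 log units; beyond the scatter), and compound 3 lies nearest. Compound 4, `O[C@@H]1[C@H](O)[C@@H]2C[C@@H]2[C@H]1n1cnc2c(NCc3cc(F)ccc3F)nc(Cl)nc21`, is not yet measured. It differs from compound 2 in one place: 2,5-difluorophenyl in place of 2-fluoroethyl on a saturated chain carbon bound to a nitrogen on an aromatic ring. The step from compound 2 to compound 3 bears most directly on this change, as it too puts an aromatic ring on the saturated chain carbon bound to a nitrogen on an aromatic ring, and it read a 3.1-fold lower number from compound 2 to compound 3 (0.50 log units; beyond the scatter). The step between compound 1 and compound 2 concerns another position and speaks only to the spread of the series. A modest lowering of the number is therefore expected, a 2.7-fold lower number from compound 2 to compound 4 (0.43 log units; beyond the scatter). Compound 4 is estimated at 12 nM, within 4 nM to 40 nM.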

Compound 4, inhibition constant: 16.5 nM
Beside the measured number, compound 4's estimate is 1.4-fold (0.14 log units) below it; the range from low to high includes it.
By their numbers in this assay, from the lowest: compounds 3, 4 and 2 (each within the scatter of the next, the first and the last beyond it); then compound 1.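

In this assay the 2,5-difluorobenzyl group on a nitrogen on an aromatic ring reads no differently from the two fluorine-bearing groups before it, with a 2.0-fold lower number from compound 2 to compound 4 (0.29 log units; within the scatter) and a 1.6-fold higher number from compound 3 to compound 4 (0.20 log units; within the scatter) both inside the scatter. So a benzyl carrying only fluorine serves here as well as 3-fluoropropyl, and the gap to cycloheptyl stays large at a 34-fold lower number from compound 1 to compound 4 (1.53 log units; beyond the scatter) in this series. Nothing measured here accounts for these readings. The compounds shown leave open how an unsubstituted benzyl would read at this place, and how a benzyl carrying an amine would.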